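Moving the Methyl Off the Ring, Into the Chain

A few compounds are considered here, and "the series" means these few. Any claim that something is new, unique, unknown or untested is made for them only; others in the source may bear on it.

Compound 1 `CCCCc1cnc(CCCc2ccc(-c3ccccc3C(=O)O)cc2)[nH]1`: 5600 nM
Compound 2 `Cc1ccccc1Cc1cnc(CCc2ccc(-c3ccccc3C(=O)O)cc2)[nH]1`: 127 nM
Compound 3 `CCCCc1cnc(C(CCCC)Cc2ccc(-c3ccccc3C(=O)O)cc2)[nH]1`: 2660 nM

Of the compounds shown here, three have been measured in an in vitro functional assay on cells for agonist activity at Bombesin receptor subtype-3 (Homo sapiens), read by luminescence and calcium flux; a higher number here means that more compound is needed for the effect, a lower number that less compound is needed. Compound 2 stands lowest of the three: in this assay compound 2 gives 127 nM, and the gaps to compound 3 and to compound 1 both lie beyond the usual scatter. Compound 4 `O=C(O)c1ccccc1-c1ccc(CCc2ncc(CCc3ccccc3)[nH]2)cc1` has not yet been measured. It differs from compound 2 in one way: benzyl in place of 2-methylphenyl on a saturated chain carbon bound to an aromatic carbon. Among the measured compounds shown here, compounds 1 and 3 carry a different group at that place and also differ elsewhere in the chain, so no measured pair isolates this single change. The step from compound 2 to compound 4 is expected to be a modest rise, a 2.4-fold higher number from compound 2 to compound 4 (0.37 log units; beyond the scatter). Compound 4 is estimated at 300 nM, within a range from 80 nM to 1200 nM.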

Compound 4, half-maximal effective concentration: 1320 nM
Estimate against measurement, compound 4: 4.4-fold (0.64 log units) below, and the stated range ends below it.
By their numbers in this assay, from the lowest: compound 2; then compounds 4 and 3 (each within the scatter of the next); then compound 1.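

Benzyl in place of 2-methylphenyl on a saturated chain carbon bound to an aromatic carbon gives a 10-fold higher number from compound 2 to compound 4 (1.02 log units; beyond the scatter) in this assay, even though the two compounds hold the same atoms. At this place, then, how those atoms are joined matters and not merely how many there are: 2-methylbenzyl and phenethyl count alike but read far apart. Nothing in the data shown gives a reason for this step.

Still open, on these data alone, is whether the methyl itself or the way the ring joins the chain carries the difference. A 2-chlorobenzyl or a cyclohexylmethyl group at this place would bear on that.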